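The source may hold more compounds than are shown below. What is called first, only, known or untested is meant among the compounds shown, and "the series" means these compounds.

Measured in a functional assay on Bel-7402 cells (Homo sapiens) for cytotoxicity, read by MTT assay; a higher number here means a weaker inhibitor, a lower number a stronger inhibitor:
Compound 1 `CC1(C)C2CCC1(C)C(OC(=O)/C=C/c1ccc(O)c(O)c1[N+](=O)[O-])C2`: 28700 nM
Compound 2 `COc1cc(/C=C/C(=O)OCCc2ccccc2)cc([N+](=O)[O-])c1O`: > 300000 nM, a limit of the assay
Compound 3 `O=C(/C=C/c1ccc(O)c(O)c1[N+](=O)[O-])OCCc1ccccc1`: 10200 nM

Of the two exact numbers, compound 1 holds the higher, and compound 3 lies lower by more than the scatter. Compound 4 `CC1(C)C2CCC1(C)C(OC(=O)/C=C/c1ccc(O)c(O)c1)C2` differs from compound 1 by having hydrogen in place of nitro on an aromatic carbon. Going by the values given here, no measured pair isolates this change, so its effect in this assay remains open. A small step of no firm direction is expected, possibly none beyond the scatter. The expected step is a 1.2-fold lower number from compound 1 to compound 4 (0.08 log units; within the scatter). For compound 4 the estimated value is 24000 nM, with an expected range from 7000 nM to 80000 nM.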

Compound 4, half-maximal inhibitory concentration: 28200 nM
Compound 4: the middle estimate sits 1.2-fold (0.07 log units) below what was measured; the measured number falls inside the stated range.
By their numbers in this assay, from the lowest: compound 3; then compounds 4 and 1 (each within the scatter of the next). At a limit, above all of these: compound 2.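

In this assay, hydrogen in place of nitro on this aromatic carbon, ortho to a hydroxy group, gives a step within the scatter: a 1.0-fold lower number from compound 1 to compound 4 (0.01 log units; within the scatter). Going by these compounds alone, this pair is the only one that isolates the change, and it shows that on the core of compound 1 the nitro group at this position is not required for the cytotoxicity read here. Nothing given here explains this result.

From the compounds shown here alone, whether the same change behaves alike with the ester of compound 3 remains open. Also open, going by these compounds, is how an amine or a carboxylic acid on this aromatic carbon would read.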